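The source may hold more compounds than are shown below. What is called first, only, known or untested is meant among the compounds shown, and "the series" means these compounds.

Of the compounds shown here, three with a related core have been tested in a functional assay on DU-145 cells (Homo sapiens) for antiproliferative activity, read by MTT assay, with a stated time of 24 h; a lower number here means a stronger inhibitor, a higher number a weaker inhibitor. Compound 1 `c1ccc(-c2noc(-c3ccncc3)n2)cc1` gives 657000 nM, a measured number. Compound 2 `COc1ccc(-c2noc(-c3ccncc3)n2)cc1OC1CCCC1` gives > 1000000 nM, which is a limit of the assay and not a number. Compound 3 `COc1ccc(-c2noc(Cc3c[nH]c4ccccc34)n2)cc1OC1CCCC1` gives > 1000000 nM, which is also a limit and not a number. From the compounds shown here alone, compound 2 therefore stands at the limit of > 1000000 nM in this assay, at which 2 of the 3 values shown sit, and its true value remains unknown.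

Compound 4 `COc1ccc(-c2noc(-c3ccc(F)cc3)n2)cc1OC1CCCC1` has not yet been measured. It differs from compound 2 in one place, with 4-fluorophenyl in place of pyridin-4-yl on an aromatic carbon. Going by the values given here, no pair of measured compounds shows this change on its own, so the data give no direct guide to its size. Among the compounds with values here, the closest guide is the only measured number, from compound 1 at 657000 nM, which suggests that weak activity is the likely outcome. The estimated change, an at least 1.4-fold lower number from compound 2 to compound 4 (0.15 log units; that floor lies within the scatter), is expected to be modest and to point, if anywhere, towards a lower number. A result at the same limit would also be no surprise. For compound 4, the expected value is 700000 nM, with an estimated range from 250000 nM to 1000000 nM.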

Compound 4, half-maximal inhibitory concentration: 20700 nM
Beside the measured number, compound 4's estimate is 34-fold (1.53 log units) above it; measured number below the stated range.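

In this assay, 4-fluorophenyl in place of pyridin-4-yl on this aromatic carbon gives an at least 48-fold lower number from compound 2 to compound 4 (1.68 log units; beyond the scatter), a large step that lies beyond the scatter. Going by these compounds alone, this is the first sign that the group at this place can strongly change the read-out, as the earlier compounds offered no step between measured compounds that differ in one place. The size printed for this step is only a floor, and the true gap may be larger, as compound 2 holds a limit and not a number: the limit of > 1000000 nM in this assay, at which 2 of the 4 values shown sit.

The change does two things at once, removing the ring nitrogen of pyridin-4-yl and bringing in a fluorine, and the compounds shown cannot tell which of the two matters, or whether both do. A plain phenyl group at this place, with the rest of compound 2 kept the same, would separate the two parts of the change, and a 4-chlorophenyl or 4-aminophenyl group would show whether the fluorine can be replaced by another atom or group.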